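The source may hold more compounds than are shown below. What is called first, only, known or untested is meant among the compounds shown, and "the series" means these compounds.

Compound 1 `O=C1C=C(Nc2ccc(I)cc2)C(=O)c2c1nc1n2[C@H]2OC[C@@H](O)[C@H]2OC1`: 1400 nM in a functional assay on MGC-803 cells (Homo sapiens) for inhibition, read by sulforhodamine B assay; a lower number here means a stronger inhibitor, a higher number a weaker inhibitor. Compound 3 `O=C1C=C(Nc2ccccc2)C(=O)c2c1nc1n2[C@H]2OC[C@@H](O)[C@H]2OC1`: 1730 nM. Compound 2 `O=C1C(N2CCCCC2)=CC(=O)c2c1nc1n2[C@H]2OC[C@@H](O)[C@H]2OC1`: a limit only, > 4000 nM.

Compound 2 stands at the limit of > 4000 nM in this assay, at which 1 of the 3 values shown sits, so for it there is no number, only a limit. For the measured compounds named here, the single measured step, a 1.2-fold higher number from compound 1 to compound 3 (0.09 log units; within the scatter), concerns the aromatic ring and does not touch the change from compound 2 to compound 4, (cyclohexylamino in place of piperidin-1-yl on a double-bonded ring carbon). Going by the values given here, no measured pair bears directly on this change. Compound 4 `O=C1C(NC2CCCCC2)=CC(=O)c2c1nc1n2[C@H]2OC[C@@H](O)[C@H]2OC1` shares with the anilino compounds a hydrogen-bond donor at that position, and compound 1 gives 1400 nM while compound 3 gives 1730 nM. Compound 4 is therefore expected in this assay near 3000 nM, between 1200 nM and 8000 nM. The step of an at least 1.3-fold lower number from compound 2 to compound 4 (0.12 log units; that floor lies within the scatter) is expected, with a real chance that only a limit is returned again.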

Compound 4, half-maximal inhibitory concentration: > 8000 nM
Compound 4 gave a limit, no number (the forecaster's own chance of this, stated with the estimate: 35%); middle value at least 2.6-fold (0.42 log units) from the limit.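

Compound 2 and compound 4 each return only a limit, not a number, so the step between them cannot be read. The compounds shown leave open whether cyclohexylamino in place of piperidin-1-yl changes inhibition at all.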